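A few compounds are considered here, and "the series" means these few. Any claim that something is new, unique, unknown or untested is made for them only; others in the source may bear on it.

Compounds measured so far:
- compound 1 `C=C1C(=O)OC[C@@H]1CCOC(=O)Nc1ccc(C(C)C)cc1`: in a functional assay on RAW264.7 cells (Mus musculus) for inhibition, with a stated time of 30 min (on this read-out lower numbers stand for stronger inhibition and higher numbers for weaker inhibition), compound 1 gives 1580 nM
- compound 2 `C=C1C(=O)OC[C@@H]1CCOC(=O)Nc1ccccc1`: in this assay compound 2 gives 780 nM

Among the compounds with values here, compound 2 stands at the lowest of the two numbers, with compound 1 as its only neighbour, giving a 2.0-fold lower number from compound 1 to compound 2 (0.31 log units; beyond the scatter) when the isopropyl group is replaced by hydrogen on the aromatic carbon. Compound 3 `C=C1C(=O)OC[C@@H]1CCOC(=O)Nc1ccc(Br)cc1` is not yet measured; it differs from compound 2 by bromo in place of hydrogen on an aromatic carbon, the new group sitting on an aromatic carbon of a six-membered aromatic ring of carbon only, para to a large group. Within the data shown here, the only step that bears on this change is the one from compound 1 to compound 2, which shows that placing a group at this position gave a modest, real rise in the number. Bromo is a different group from isopropyl, so the expectation is only a modest step upward in this assay, with a 1.4-fold higher number from compound 2 to compound 3 (0.15 log units; within the scatter) as the estimated change, possibly within the scatter. For compound 3 the expected value is 1100 nM, in a range from 450 nM to 2700 nM.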

Compound 3, half-maximal inhibitory concentration: 720 nM
Compound 3: the middle estimate sits 1.5-fold (0.18 log units) above what was measured; the range from low to high includes it.
By their numbers in this assay, from the lowest: compounds 3 and 2 (each within the scatter of the next); then compound 1.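

In this assay, bromo in place of hydrogen on this aromatic carbon gives a 1.1-fold lower number from compound 2 to compound 3 (0.03 log units; within the scatter) and so leaves the number unchanged within the scatter, which shows that filling this position does not in itself raise the number. Swapping one group for the other at the same place gives a 2.2-fold lower number from compound 1 to compound 3 (0.34 log units; beyond the scatter) and so the two groups are not interchangeable here: the rise seen with isopropyl does not appear with bromo. No measurement at hand explains why these two groups part ways.

Only hydrogen, isopropyl and bromo are shown at this position, so it remains open whether fluoro, an amine or a carboxylic acid would match hydrogen and bromo or move the number. As far as these compounds go, whether bromo behaves the same way on other carbons of the ring also remains open.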